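Furan-2-yl for pyridin-2-yl on the shared core

The source may report more compounds than this note shows. Statements on the series, on what has been measured and on what is new or still open speak of the compounds shown alone.

Compound 1 `O=C(Nc1ccc(-c2cscn2)cc1)C1CCCN(Cc2ccccc2F)C1` gives 7000 nM
Compound 2 `O=C(Nc1ccc(-c2cscn2)cc1)C1CCCN(Cc2cccc(C(F)(F)F)c2)C1` gives > 20000 nM
Compound 3 `O=C(Nc1ccc(-c2ccccn2)cc1)C1CCCN(Cc2ccc(F)c(F)c2)C1` gives 11000 nM

In a functional assay on A-375 cells (Homo sapiens) for activation, with a stated time of 3 days (on this read-out higher numbers stand for an effect only at larger amounts of compound and lower numbers for an effect already at smaller amounts), compound 3 stands at 11000 nM within the scatter of compound 1 at 7000 nM and so apart from it by nothing firm. The entry for compound 2 (> 20000 nM) is a limit of the assay. Compound 4 `O=C(Nc1ccc(-c2ccco2)cc1)C1CCCN(Cc2ccc(F)c(F)c2)C1` carries furan-2-yl in place of pyridin-2-yl on an aromatic carbon. Going by the values given here, the only measured step (an at least 2.8-fold higher number from compound 1 to compound 2 (0.45 log units; beyond the scatter)) lies at another place, 3-(trifluoromethyl)phenyl in place of 2-fluorophenyl, and no measured step touches pyridin-2-yl. Starting from compound 3 at 11000 nM in this read-out, the change to compound 4 is therefore expected to stay within the scatter. The estimated change is small (a 1.1-fold lower number from compound 3 to compound 4 (0.04 log units; within the scatter)). Compound 4 is expected at 10000 nM within an estimated range of 4000 nM to 20000 nM for this read-out.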

Compound 4, half-maximal effective concentration: 2200 nM
For compound 4 the middle estimate is 4.5-fold (0.66 log units) above the measured one; the measured number lies below the stated range.
By their numbers in this assay, from the lowest: compound 4; then compounds 1 and 3 (each within the scatter of the next). At a limit, above all of these: compound 2.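

In this assay, the group on this aromatic carbon, para to a large group, proves able to move the number: furan-2-yl in place of pyridin-2-yl gives a 5.0-fold lower number from compound 3 to compound 4 (0.70 log units; beyond the scatter). The two groups have the same counts of hydrogen-bond donors and acceptors, and neither carries a net charge, so those counts do not separate them. Nothing measured here accounts for the step.

From the compounds shown here alone, whether thiophen-2-yl or a plain phenyl would serve at this position remains open. So does whether furan-2-yl gives a similar step alongside 2-fluorophenyl.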